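This account rests on a few compounds, and the source may have more. Where it says the series, first, only, none or still open, it means among the compounds named here.

Compound 1, `CCC(CC)C(N)CCN(C(=O)[C@@H]1C[C@H]1c1ccccc1)c1ccc(-c2ccccc2)cc1`, is the strongest point of reference here: in a functional assay for agonist activity at G protein-coupled receptor 88 (Homo sapiens), read by HTRF and cAMP accumulation (on this read-out lower numbers stand for an effect already at smaller amounts and higher numbers for an effect only at larger amounts of compound), compound 1 gives 2 nM. Compound 2, `CC[C@H](C)[C@H](N)CN(C(=O)[C@@H]1C[C@H]1c1ccc(C#N)cc1)c1ccc(-c2ccccc2)cc1`, shares the same core but carries a different chain on the amine side and a 4-cyanophenyl on the three-membered ring. For compound 2 the assay reported no number but only a limit, > 25000 nM; this is the limit of > 25000 nM in this assay, at which 1 of the 2 values shown sits, so compound 2 sits at the edge of what this assay can resolve. For the measured compounds named here, no step between these two measured compounds can be stated, because they differ in more than one place; their two values simply show that one is potent and the other is beyond the measurable range.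

Compound 3, `CC[C@H](C)[C@H](N)CN(C(=O)[C@@H]1C[C@H]1c1nc(C)cs1)c1ccc(-c2ccccc2)cc1`, is not yet measured. It keeps everything of compound 2 except one change: 4-methyl-1,3-thiazol-2-yl in place of 4-cyanophenyl on a saturated ring carbon. With compound 2 at a limit, any movement can only be toward smaller numbers or none at all. The expected step of an at least 3.1-fold lower number from compound 2 to compound 3 (0.49 log units; beyond the scatter) is modest. Compound 3 is estimated at 8000 nM, with a likely range from 500 nM to 25000 nM.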

Compound 3, half-maximal effective concentration: 730 nM
Compound 3: the middle estimate sits 11-fold (1.04 log units) above what was measured, within the range that was stated.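

On the three-membered ring, the 4-cyanophenyl gives way to 4-methyl-1,3-thiazol-2-yl, and this exchange gives an at least 34-fold lower number from compound 2 to compound 3 (1.53 log units; beyond the scatter) in this assay. Compound 2 has only a limit and not a number, so this step is a minimum and its full size cannot be read: the limit of > 25000 nM in this assay, at which 1 of the 3 values shown sits. Even so, compounds 2 and 3 differ in this one place only, which shows that the group held here can decide whether a compound with this amine side chain gives a measurable effect in this assay at all.

The compounds shown leave open whether the gain comes from the five-membered ring itself, from its methyl group or simply from losing the 4-cyanophenyl, and an unsubstituted 1,3-thiazol-2-yl, a 4-methylphenyl or a plain phenyl on this same amine side chain would help to separate these possibilities. As far as these compounds go, compound 1 differs from compounds 2 and 3 in more than one place, so the part played by its longer amine side chain remains open as well.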